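Same atoms, joined differently, in one side chain

A few compounds are considered here, and "the series" means these few. Any claim that something is new, unique, unknown or untested is made for them only; others in the source may bear on it.

Among the measured compounds shown here, in a functional assay on RAW264.7 cells (Mus musculus) for inhibition, read by Griess assay, with stated times of 1 h and 24 h (a higher number here means a weaker inhibitor, a lower number a stronger inhibitor), compound 2 `COCCCOc1ccc(C(O)C2OC(=O)c3c(OC)cc(OC)cc32)cc1` gives 1260 nM, the lower of the two numbers so far, which makes it the stronger inhibitor of the pair. The other measured compound, compound 1 `CCCCCCOc1ccc(C(O)C2OC(=O)c3c(OC)cc(OC)cc32)cc1`, gives 5360 nM. Compound 3 `CCOCCOc1ccc(C(O)C2OC(=O)c3c(OC)cc(OC)cc32)cc1` keeps the shared core and has the same atoms as compound 2, joined differently: ethoxy in place of methoxymethyl on a saturated chain carbon, two bonds along the chain from an oxygen on an aromatic ring. Put simply, it has ethoxy in place of methoxymethyl on a saturated chain carbon, two bonds along the chain from an oxygen on an aromatic ring.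

For the measured compounds named here, only one measured step bears on this, and only loosely. It is modest, a 4.3-fold lower number from compound 1 to compound 2 (0.63 log units; beyond the scatter), and it came with methoxy in place of propyl, a change in which atoms the chain holds. Going by the values given here, in compound 3 those atoms stay the same and only their order changes, and no measured pair shows what such a reshuffle does. A shift beyond the scatter, in either direction, is therefore not expected. The step expected in this assay is small, a 1.1-fold higher number from compound 2 to compound 3 (0.05 log units; within the scatter). For compound 3 the estimated value is 1400 nM, with an expected range of 550 nM to 3600 nM.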

Compound 3, half-maximal inhibitory concentration: > 10000 nM
Compound 3: a limit, no number; the forecaster's own chance of this, stated with the estimate: 3%; middle value at least 7.1-fold (0.85 log units) from the limit.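

Rejoining the same atoms in the side chain, with ethoxy in place of methoxymethyl, gives an at least 7.9-fold higher number from compound 2 to compound 3 (0.89 log units; beyond the scatter) and so shows that in this assay this position answers to how the chain is arranged and not only to which atoms it holds. Compound 3 stands at a limit of the assay and not at a number, so that step is a floor and the true gap may be wider: the limit of > 10000 nM in this assay, at which 1 of the 3 values shown sits. The comparison with the chain that carries no second oxygen is less firm, with an at least 1.8-fold higher number from compound 1 to compound 3 (0.27 log units; that floor lies within the scatter) and so this floor alone sets no clear gap between those two.

From the compounds shown here alone, how far compound 3 really lies past its limit stays unknown, and two oxygen-bearing chains are too few to tell whether the arrangement in compound 2 is a rare good fit or one of many. Also open, going by these compounds, is whether a side chain carrying an amine or a carboxylic acid, or a longer chain holding an ether oxygen, would bring the number below that of compound 2.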